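The compounds below may be only part of what the source reports. "The series", "measured", "known", "first", "only" and "open" are said of these compounds alone.

Working notes on the series.

Three compounds share one core and differ only in the group on the terminal amide-type nitrogen of the urea. Compound 1 `COc1cc2cc(Oc3ccc(NC(=O)Nc4ccccc4)cc3)c(C)nc2cc1OC` carries an unsubstituted phenyl there and in a functional assay on U-251 cells (Homo sapiens) for inhibition, read by sulforhodamine B assay, with a stated time of 48 h, tested at 10 uM (a lower number here means a stronger effect, a higher number a weaker effect of the compound at the concentration tested), compound 1 gives 48%. Compound 2 `COc1cc2cc(Oc3ccc(NC(=O)Nc4ccc(C)cc4)cc3)c(C)nc2cc1OC` carries a methyl on that ring, and in this assay compound 2 gives 99.9%. Compound 3 `COc1cc2cc(Oc3ccc(NC(=O)Nc4ccc(C(F)(F)F)cc4)cc3)c(C)nc2cc1OC` carries a trifluoromethyl, and in this assay compound 3 gives 15%. The steps are all large: a number 51.9 percentage points higher from compound 1 to compound 2 (beyond the scatter), a number 33 percentage points lower from compound 1 to compound 3 (beyond the scatter) and a number 84.9 percentage points lower from compound 2 to compound 3 (beyond the scatter). Compound 3 thus stands lowest of the three numbers, with compound 1 nearest and compound 2 furthest.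

Compound 4 `COc1cc2cc(Oc3ccc(NC(=O)Nc4cccc(C(F)(F)F)c4)cc3)c(C)nc2cc1OC` is the next case. The change from compound 3 is 3-(trifluoromethyl)phenyl in place of 4-(trifluoromethyl)phenyl on an amide-type nitrogen. For the measured compounds named here, none of the measured steps bears directly on this kind of change: each of them exchanges one group for another at the same position of the ring, whereas here the same group moves to another position. Going by the values given here, the three measured steps show only that this ring tolerates large swings in this assay. The estimate for compound 4 in this assay is therefore wide, 35% with a range from 10% to 75%. The step this expectation means is a number 20 percentage points higher from compound 3 to compound 4 (beyond the scatter), that is, a number somewhat higher than for compound 3, since compound 3 is the extreme of the series and a move away from it is the more likely outcome.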

Compound 4, a percentage reported as activity, at one concentration (the size of the read-out at that concentration, not a potency): -85.7%
Beside the measured number, compound 4's estimate is 120.7 percentage points above it; measured number below the stated range.
By their numbers in this assay, from the lowest: compound 4; then compound 3; then compound 1; then compound 2.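

In this assay, moving the same trifluoromethyl group from 4-(trifluoromethyl)phenyl to 3-(trifluoromethyl)phenyl on the amide-type nitrogen gives a number 100.7 percentage points lower from compound 3 to compound 4 (beyond the scatter), so the place of an unchanged group on this ring can by itself produce a large change, something the earlier exchanges of one group for another could not show. Compound 4 also lies far from the other two compounds, with a number 133.7 percentage points lower from compound 1 to compound 4 (beyond the scatter) and a number 185.6 percentage points lower from compound 2 to compound 4 (beyond the scatter), which makes it the lowest of the four and the first with a negative read-out. No available evidence explains the effect of this change.

The compounds shown leave open whether 3-methylphenyl would differ from the 4-methylphenyl of compound 2 in the same direction, so the shift cannot yet be called general for groups on this ring. It also remains open whether an amine, a carboxylic acid or a nitrile in place of trifluoromethyl on the 3-substituted phenyl would follow compound 4, and how any of these compounds would behave at other concentrations in this assay.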